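Shifting a Fluorine Along the Phenethyl Aryl Ring

The compounds below may be only part of what the source reports. "The series", "measured", "known", "first", "only" and "open" are said of these compounds alone.

Compound 2 `Cc1cc(NC(=O)CC(=O)O)c2c(c1Oc1ccc(O)c(CCc3ccc(F)cc3F)c1)CCC2` gives 12 nM in an in vitro assay on cells for displacement of a labelled ligand from thyroid hormone receptor beta (Homo sapiens), with a stated time of 48 h (a lower number here means a stronger inhibitor, a higher number a weaker inhibitor), and stands alongside compound 1 `Cc1cc(NC(=O)CC(=O)O)c2c(c1Oc1ccc(O)c(CCc3ccc(F)cc3)c1)CCC2`, which gives 8.2 nM; the step of a 1.5-fold higher number from compound 1 to compound 2 (0.17 log units; within the scatter) lies within the scatter. Compound 3 `Cc1cc(NC(=O)CC(=O)O)c2c(c1Oc1ccc(O)c(CCc3ccc(F)c(F)c3)c1)CCC2` differs from compound 2 by 3,4-difluorophenyl in place of 2,4-difluorophenyl on a saturated chain carbon, two bonds along the chain from an aromatic carbon. Going by the values given here, no measured step moves a fluorine from one ring carbon to another; the single measured step, from compound 1 to compound 2, adds a fluorine and stays within the scatter. For compound 3 the expected step is therefore a 1.1-fold lower number from compound 2 to compound 3 (0.04 log units; within the scatter), nothing beyond the scatter. Compound 3 is estimated at 11 nM, with a range from 5 nM to 25 nM.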

Compound 3, inhibition constant: 6 nM
Compound 3: the middle estimate sits 1.8-fold (0.26 log units) above what was measured; measured number inside the range.
By their numbers in this assay, from the lowest: compounds 3, 1 and 2 (each within the scatter of the next).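

The swap of 2,4-difluorophenyl for 3,4-difluorophenyl gives, in this assay, a 2.0-fold lower number from compound 2 to compound 3 (0.30 log units; within the scatter) and so supplies the first measured move of a fluorine around this ring. Adding a fluorine to the ring of compound 1 at the other place gives a 1.4-fold lower number from compound 1 to compound 3 (0.14 log units; within the scatter) and, like the earlier addition, stays inside the scatter, so these three compounds cannot be told apart at this position. Nothing at hand bears on why the numbers fall as they do. The compounds shown leave open whether a group other than fluoro on this ring, such as chloro or methoxy, or a longer chain in place of the ethyl link, would give a step beyond the scatter.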